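Urea in Place of Aryl Thiourea: Expected Cytotoxicity

The source may report more compounds than this note shows. Statements on the series, on what has been measured and on what is new or still open speak of the compounds shown alone.

Three compounds share one core and differ only at the substituent on an amide-type nitrogen. Compound 1 `C=CCNC(=S)NC1=C(C#N)C(c2ccc(Cl)cc2Cl)C2=C(CCCC2=O)N1c1ccc(S(N)(=O)=O)cc1` carries an allyl group; in a functional assay on Ehrlich cells (Mus musculus) for cytotoxicity, read by trypan blue exclusion, with a stated time of 2 h, tested at 10 ug/mL (on this read-out lower numbers stand for a weaker effect and higher numbers for a stronger effect at the one concentration tested), compound 1 gives 10%. Compound 2 `N#CC1=C(NC(=S)Nc2ccccc2)N(c2ccc(S(N)(=O)=O)cc2)C2=C(C(=O)CCC2)C1c1ccc(Cl)cc1Cl` bears a phenyl at that place, and in this assay compound 2 gives 40%. Compound 3 `N#CC1=C(NC(=S)Nc2ccc(Cl)cc2)N(c2ccc(S(N)(=O)=O)cc2)C2=C(C(=O)CCC2)C1c1ccc(Cl)cc1Cl` bears a 4-chlorophenyl; in this assay compound 3 gives 30%. On these numbers compound 3 sits second of the three, within the scatter of compound 2 and beyond the scatter above compound 1. The measured steps are a number 30 percentage points higher from compound 1 to compound 2 (beyond the scatter) and a number 20 percentage points higher from compound 1 to compound 3 (beyond the scatter), whereas a number 10 percentage points lower from compound 2 to compound 3 (within the scatter).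

Compound 4 `N#CC1=C(NC(N)=O)N(c2ccc(S(N)(=O)=O)cc2)C2=C(C(=O)CCC2)C1c1ccc(Cl)cc1Cl` is not yet measured. It differs from compound 3 as follows: a group of 3 heavy atoms (1 carbon, 1 nitrogen, 1 oxygen; no ring) in place of a group of 10 heavy atoms (7 carbon, 1 nitrogen, 1 sulfur, 1 chlorine; one six-membered aromatic ring of carbon only), on an amine nitrogen. The aromatic ring and the sulfur both leave, and only a carbamoyl remains on the amine nitrogen. Within the data shown here, the steps that bear on this are the two from compound 1, which lacks an aromatic ring at the same place and gives the lowest number of the three; both aryl replacements raised the read-out by a modest amount. A move back toward a small, ring-free group is therefore expected to lower this assay, and the step of a number 15 percentage points lower from compound 3 to compound 4 (beyond the scatter) is the estimate. For compound 4 the expected value in this assay is 15%, with a range from 0% to 35%.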

Compound 4, a percentage reported as activity, at one concentration (the size of the read-out at that concentration, not a potency): 20%
Compound 4: middle estimate off by 5 percentage points, on the low side, and the stated range covers the measured number.
By their numbers in this assay, from the lowest: compounds 1, 4, 3 and 2 (each within the scatter of the next, the first and the last beyond it).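

Working notes. In this assay, replacing the aryl thiocarbamoyl group with a carbamoyl on the amine nitrogen gives one step beyond the scatter, only against the phenyl compound (a number 20 percentage points lower from compound 2 to compound 4 (beyond the scatter)). The other two steps stay within the scatter (a number 10 percentage points lower from compound 3 to compound 4 (within the scatter); a number 10 percentage points higher from compound 1 to compound 4 (within the scatter)), so compound 4 cannot be told apart from compound 3 or compound 1, even though those two are themselves separated (a number 20 percentage points higher from compound 1 to compound 3 (beyond the scatter)); a group with no aromatic ring and no sulfur therefore keeps a measurable read-out at this position, and its place in the series stays unresolved except against compound 2. No supporting data bear on why this read-out follows these changes.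

The ring and the sulfur leave together in this change, so the compounds shown do not divide the step from compound 2 between them; a phenylcarbamoyl group, which keeps the phenyl and has oxygen in place of sulfur, would separate the two. Also open, as far as these compounds go, is how a benzyl group, a longer alkyl chain or an unsubstituted thiocarbamoyl group would read at this amine nitrogen.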